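Amide-nitrogen swap on compound 2: working notes

The compounds below may be only part of what the source reports. "The series", "measured", "known", "first", "only" and "open" are said of these compounds alone.

Measured in a functional assay on SK-BR-3 cells (Homo sapiens) for cytotoxicity, read by MTT assay, with a stated time of 72 h; on this read-out lower numbers stand for stronger inhibition and higher numbers for weaker inhibition:
- compound 1 `CN(C)CCCNc1c(C(=O)NCc2ccc(F)cc2)nc(Br)c2cccnc12`: 1000 nM
- compound 2 `COc1cccc(CNC(=O)c2nc(Br)c3cccnc3c2N[C@H]2CC[C@H](N)CC2)c1`: 6000 nM
- compound 3 `O=C(NCCCNc1c(C(=O)NCc2ccc(F)cc2)nc(Br)c2cccnc12)c1ccccc1`: 1000 nM

Compound 2 stands highest of the three at 6000 nM, beyond the scatter from both others. Compound 4 `C[C@H](NC(=O)c1nc(Br)c2cccnc2c1N[C@H]1CC[C@H](N)CC1)c1ccc(F)cc1` carries 1-(4-fluorophenyl)ethyl in place of 3-methoxybenzyl on an amide-type nitrogen. Going by the values given here, the only measured step, no change at the digits printed from compound 1 to compound 3 (within the scatter), is a change on a saturated chain and not at this nitrogen. It shows tolerance there but does not size the present change. Among the compounds with values here, no measured step covers this swap, so a wide range is kept and only a slight move toward lower numbers is expected. The expected step is a 1.7-fold lower number from compound 2 to compound 4 (0.23 log units; within the scatter). For compound 4 the estimate in this assay is 3500 nM, with an expected range from 1000 nM to 12000 nM.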

Compound 4, half-maximal inhibitory concentration: 9000 nM
For compound 4 the middle estimate is 2.6-fold (0.41 log units) below the measured one; the range from low to high includes it.
By their numbers in this assay, from the lowest: compounds 1 and 3 (each within the scatter of the next); then compounds 2 and 4 (each within the scatter of the next).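

In this assay, the first step read at this amide-type nitrogen is a 1.5-fold higher number from compound 2 to compound 4 (0.18 log units; within the scatter). Compound 2 and compound 4 therefore cannot be told apart here, even though 1-(4-fluorophenyl)ethyl differs from 3-methoxybenzyl in its defined stereocentre and in carrying fluorine instead of oxygen. No supporting data bear on this result.

Open, on these data alone, is whether the stereocentre and the ring substituent would each matter if read alone. Also open, as far as these compounds go, is whether a longer chain such as 2-phenylethyl, or a carboxylic acid, would be accepted on this nitrogen.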